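Lengthening the Chain from Compound 3 to Compound 4

A few compounds are considered here, and "the series" means these few. Any claim that something is new, unique, unknown or untested is made for them only; others in the source may bear on it.

Measured compounds:
Compound 1, `CS(=O)(=O)c1ccc2nc(NC(=O)CCCCC(=O)NO)sc2c1`, in a functional assay on PC-3 cells (Homo sapiens) for cytotoxicity (a higher number here means a weaker inhibitor, a lower number a stronger inhibitor), gives > 30 ug/mL, which is a limit of the assay and not a number.
Compound 2, `COc1ccc2nc(NC(=O)CCCCCCC(=O)NO)sc2c1`, in this assay gives 1.56 ug/mL.
Compound 3, `O=C(CCCCC(=O)Nc1nc2ccccc2s1)NO`, in this assay gives 12.5 ug/mL.

Compound 3 stands highest of the two numbers measured in this assay; compound 2 is the nearest, with a lower number beyond the scatter, while compound 1 sits at the limit of > 30 ug/mL in this assay, at which 1 of the 3 values shown sits. Going by the values given here, the only step measured between compounds that differ in one place is an at least 2.4-fold lower number from compound 1 to compound 3 (0.38 log units; beyond the scatter), and it concerns the group on the aromatic carbon, not the chain.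

Compound 4, `O=C(CCCCCCC(=O)Nc1nc2ccccc2s1)NO`, differs from compound 3 by 2-(hydroxycarbamoyl)ethyl in place of hydroxycarbamoyl on a saturated chain carbon, four bonds along the chain from a carbonyl carbon. Among the compounds with values here, no measured step bears directly on this change. Within the data shown here, compound 2 and compound 3 differ both in this chain length and in the group on the aromatic carbon, so their two values show only that the longer-chain compound gives the lower number; how much of that comes from the chain cannot be separated.

The author therefore expects a lower number for compound 4 in this assay, a step of a 3.6-fold lower number from compound 3 to compound 4 (0.55 log units; beyond the scatter), with the direction taken from what compound 2 at 1.56 ug/mL shows against compound 3. Compound 4 is estimated at 3.5 ug/mL, in the range 1.2 ug/mL to 10 ug/mL.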

Compound 4, half-maximal inhibitory concentration: 5.44 ug/mL
The estimate for compound 4 lay 1.6-fold (0.19 log units) below the measured number; the measured number falls inside the stated range.
By their numbers in this assay, from the lowest: compound 2; then compound 4; then compound 3. At a limit, above all of these: compound 1.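

In this assay, the chain change can now be read on its own, with hydrogen on the aromatic carbon in both compounds: 2-(hydroxycarbamoyl)ethyl in place of hydroxycarbamoyl gives a 2.3-fold lower number from compound 3 to compound 4 (0.36 log units; beyond the scatter). The same result isolates the group on the aromatic carbon at the longer chain length, where hydrogen in place of methoxy gives a 3.5-fold higher number from compound 2 to compound 4 (0.54 log units; beyond the scatter), so each change taken alone moves the number beyond the scatter, and neither step is more than modest. No measurement shown here bears on why either change moves the number in this assay.

The compounds shown leave open whether a longer chain would lower the number further or reverse the direction, since the chain change is read at only one pair of lengths and with hydrogen on the aromatic carbon. They also leave open whether methoxy would have the same effect on the shorter chain, and whether a carboxylic acid or an amine in place of the hydroxycarbamoyl group would keep any of the cytotoxicity seen with compound 4.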